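Swapping the methylamino for a pyridinyloxy group

The source may hold more compounds than are shown below. What is called first, only, known or untested is meant among the compounds shown, and "the series" means these compounds.

The account begins with two measured compounds that share one core and differ only in a single group on an aromatic carbon. Compound 1 `COc1ccc(-c2ccn(CCC(C)C)c(=O)c2C#N)cc1` gives, in a functional assay on CHO cells for positive allosteric modulation of metabotropic glutamate receptor 2 (Homo sapiens), read by scintillation counting and GTPgammaS binding, with a stated time of 30 min (on this read-out lower numbers stand for smaller maximal responses and higher numbers for larger maximal responses), a maximal response of 160%. Compound 2 `CNc1ccc(-c2ccn(CCC(C)C)c(=O)c2C#N)cc1` gives in this assay a maximal response of 186%. The one step between them, a number 26 percentage points higher from compound 1 to compound 2 (beyond the scatter), is the only step measured so far, and it places compound 2 highest of the two numbers shown, with compound 1 as its nearest neighbour.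

Compound 3 `Cc1cc(Oc2ccc(-c3ccn(CCC(C)C)c(=O)c3C#N)cc2)ccn1` has not yet been measured. It differs from compound 2 in the following way: (2-methylpyridin-4-yl)oxy in place of methylamino on an aromatic carbon. The step from compound 1 to compound 2 bears on the same aromatic carbon, yet it exchanged two small groups, whereas here a much larger group enters; its modest size therefore gives only a loose guide. On that basis a step of a number 16 percentage points lower from compound 2 to compound 3 (beyond the scatter) is expected, that is, no step beyond the scatter in either direction, with a wide uncertainty. The maximal response of compound 3 in this assay is estimated at 170%, within a range from 125% to 215%.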

Compound 3, largest response reached (Emax), in percent of the reference or control that the assay uses: 266%
For compound 3 the middle estimate is 96 percentage points below the measured one, and the stated range ends below it.
By their numbers in this assay, from the lowest: compound 1; then compound 2; then compound 3.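

In this assay the aromatic carbon para to a large group proves open to far more than the exchange of two small groups: a number 80 percentage points higher from compound 2 to compound 3 (beyond the scatter) is a large step, whereas a number 26 percentage points higher from compound 1 to compound 2 (beyond the scatter) was a modest one. Keeping the oxygen and replacing only the methyl on it with 2-methylpyridin-4-yl also gives a large step, a number 106 percentage points higher from compound 1 to compound 3 (beyond the scatter), so the highest maximal response of the three comes with a ring carried on that oxygen, and the hydrogen-bond donor of the methylamino group is not needed to reach it. Nothing shown here gives a reason for the size of this rise.

The compounds leave open which part of the entering group goes with the higher maximal response: the ring nitrogen, the methyl on the ring, or the oxygen that links the ring to the core. A phenoxy group, a pyridin-4-yloxy group without the methyl, or an amine link to the same 2-methylpyridine ring would each separate one of these parts from the others.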